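Sulfamoyl for fluoro on a dihydrotriazine series

The compounds below may be only part of what the source reports. "The series", "measured", "known", "first", "only" and "open" are said of these compounds alone.

Compound 1 `CC(C)c1cccc(OCc2cccc(N3C(N)=NC(N)=NC3(C)C)c2)c1`: 8.13
Compound 2 `CC1(C)N=C(N)N=C(N)N1c1cccc(F)c1`: 7.94
Compound 3 `CC1(C)N=C(N)N=C(N)N1c1cccc(COc2cccc(NC(=N)S)c2)c1`: 8.08

Of the compounds shown here, three sharing one core have been measured in a functional assay on L5178Y cells (Mus musculus) for inhibition; a higher number here means a more potent compound, by a factor of ten per unit of this negative logarithm, a lower number a less potent compound. Going by the values given here, compound 1 gives 8.13 and compound 3 gives 8.08; the one step between them, a number 0.05 log units lower from compound 1 to compound 3 (within the scatter), lies within the scatter. Compound 2, the smallest of the three, gives 7.94; its number sits within the scatter of both compound 1 and compound 3, so the three values cannot be put in any order.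

Compound 4 `CC1(C)N=C(N)N=C(N)N1c1cccc(S(N)(=O)=O)c1` is not yet measured. It differs from compound 2 by sulfamoyl in place of fluoro on an aromatic carbon. Among the compounds with values here, no measured step touches that position or that group: the only step on record, from compound 1 to compound 3, changes a different place on a different ring, so it gives no direct guide. With the three known values falling so close together, no step beyond the scatter is expected in this assay. Compound 4 is estimated at 7.7, with a range from 7 to 8.4. The estimated step, a number 0.24 log units lower from compound 2 to compound 4 (within the scatter), is expected to stay inside the usual scatter.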

Compound 4, logarithm of the reciprocal of the active concentration, log(1/C): 5.61
Estimate against measurement, compound 4: 2.09 log units above, and the stated range ends above it.
By their numbers in this assay, from the lowest: compound 4; then compounds 2, 3 and 1 (each within the scatter of the next).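

In this assay, sulfamoyl in place of fluoro on this aromatic carbon, meta to a large group, gives a number 2.33 log units lower from compound 2 to compound 4 (beyond the scatter). Going by these compounds alone, this is the first change to move the number beyond the scatter, whereas the only earlier step, at a different place, gave a number 0.05 log units lower from compound 1 to compound 3 (within the scatter), so the series is not insensitive to every change and this exchange carries a large cost. Nothing shown here accounts for the size of this drop.

The compounds shown leave open whether the loss is particular to sulfamoyl or would also follow other groups on the same aromatic carbon, such as an amine, a carboxylic acid or a methyl sulfone. They also leave open whether adding a methyl group to the sulfamoyl nitrogen would change the result.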